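This account rests on a few compounds, and the source may have more. Where it says the series, first, only, none or still open, it means among the compounds named here.

Working notes on the series. In a functional assay on Jurkat cells (Homo sapiens) for cytotoxicity, read by luminescence and CellTiter-Glo, with a stated time of 3 days (a lower number here means a stronger inhibitor, a higher number a weaker inhibitor), compound 1 (`O=C(Nc1cc(C(F)(F)F)cc(C(F)(F)F)c1)c1cc(Br)c(-c2ccccc2)cc1O`) gives 680 nM. Compound 2 (`O=C(Nc1cc(C(F)(F)F)cc(C(F)(F)F)c1)c1ccc(Br)cc1O`) gives 930 nM, which lies within the scatter of the value for compound 1, so these two numbers do not separate the compounds. Compound 3 (`O=C(Nc1cc(C(F)(F)F)cc(C(F)(F)F)c1)c1ccc(-c2ccccc2)cc1O`) has not yet been measured. It differs from compound 2 by phenyl in place of bromo on an aromatic carbon, meta to a hydroxy group and para to a large group: phenyl in place of bromo on an aromatic carbon. For the measured compounds named here, compound 1 carries both bromo and phenyl, and no measured pair isolates this change. In this assay no step beyond the scatter is expected, resting only on compound 1 at 680 nM, which holds a phenyl and stays in this range. The expected change is a 1.2-fold lower number from compound 2 to compound 3 (0.09 log units; within the scatter). The estimate for compound 3 is 750 nM, with an expected range of 300 nM to 1800 nM.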

Compound 3, half-maximal inhibitory concentration: 1240 nM
Compound 3: the middle estimate sits 1.7-fold (0.22 log units) below what was measured; measured number inside the range.
By their numbers in this assay, from the lowest: compounds 1, 2 and 3 (each within the scatter of the next).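

In this assay, for the compounds shown here, phenyl in place of bromo on an aromatic carbon, meta to a hydroxy group and para to a large group, gives a 1.3-fold higher number from compound 2 to compound 3 (0.12 log units; within the scatter) and so brings no step the assay can separate, even though 6 heavy atoms and a ring enter where 1 bromine leaves. With the phenyl kept, hydrogen in place of the bromo of compound 1 gives a 1.8-fold higher number from compound 1 to compound 3 (0.26 log units; within the scatter) and also stays within the scatter, so the three compounds are not told apart by the bromo or by the phenyl. No measurement bears on any cause of these small steps. Open, going by these compounds, is whether a different group at this position, such as an amine or a carboxylic acid, would give a step beyond the scatter. Also open, on these data alone, is how far the number depends on the hydroxy group or the trifluoromethyl groups of the shared core.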